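Swapping ethoxy for methylsulfanyl on a cyclopropyl compound

The compounds below may be only part of what the source reports. "The series", "measured", "known", "first", "only" and "open" are said of these compounds alone.

Measured in a functional assay on MCF7 cells (Homo sapiens) for inhibition, read by resazurin assay, with a stated time of 72 h; on this read-out lower numbers stand for stronger inhibition and higher numbers for weaker inhibition:
- Compound 1 `CCSc1ccc(C2C(Oc3ccccc3)C(=O)N2c2cc(OC)c(OC)c(OC)c2)cc1`: 210 nM
- Compound 2 `CCSc1ccc(C2C(O)C(=O)N2c2cc(OC)c(OC)c(OC)c2)cc1`: 6 nM
- Compound 3 `CCOc1ccc(C2C(C3CC3)C(=O)N2c2cc(OC)c(OC)c(OC)c2)cc1`: 131 nM

In this assay, compound 3 gives 131 nM, the second highest of the three numbers. This lies within the usual scatter of compound 1, while compound 2 stands clearly lower.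

The next compound is compound 4 `COc1cc(N2C(=O)C(C3CC3)C2c2ccc(SC)cc2)cc(OC)c1OC`. The change is methylsulfanyl in place of ethoxy on an aromatic carbon, with methylsulfanyl in place of ethoxy on an aromatic carbon, para to a large group.

For the measured compounds named here, only one step has been measured, a 35-fold lower number from compound 1 to compound 2 (1.54 log units; beyond the scatter), and it is large. That step, hydrogen in place of phenyl on an oxygen on a saturated carbon, lies at a different place in the structure. Going by the values given here, it therefore says little about this change, and no measured step tests the exchange directly. Without such evidence, no step beyond the scatter is expected, and the estimated change is a 1.3-fold lower number from compound 3 to compound 4 (0.12 log units; within the scatter).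

Compound 4 is expected at about 100 nM, with an estimated range of 30 nM to 330 nM.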

Compound 4, half-maximal inhibitory concentration: 131 nM
For compound 4 the middle estimate is 1.3-fold (0.12 log units) below the measured one, and the stated range covers the measured number.
By their numbers in this assay, from the lowest: compound 2; then compounds 3, 4 and 1 (each within the scatter of the next).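

In this assay, for the compounds shown here, methylsulfanyl in place of ethoxy on an aromatic carbon, para to a large group, gives no change at the digits printed from compound 3 to compound 4 (within the scatter), the first measured step at this position. Going by these compounds alone, on the cyclopropyl compounds, this position therefore accepts the exchange of oxygen and its two-carbon chain for sulfur and its single carbon without a step beyond the scatter, whereas the only large step so far lies at the oxygen on a saturated carbon. Nothing measured here explains why the two groups read alike.

The compounds shown leave open whether an amine such as dimethylamino or a longer chain such as butoxy would stay within the scatter at this position. They also leave open whether the same exchange would read alike on compounds with a hydroxy group in place of cyclopropyl.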